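Branching the enamide chain on a fluorinated indole analogue

This account rests on a few compounds, and the source may have more. Where it says the series, first, only, none or still open, it means among the compounds named here.

Measured compounds:
- compound 1 `COc1cc(N(C)CCN(C)C)c(NC(=O)/C=C\C(C)C)cc1Nc1ncc(C#N)c(-c2cn(C)c3ccccc23)n1`: 1100 nM
- compound 2 `C=CC(=O)Nc1cc(Nc2ncc(C#N)c(-c3cn(C)c4ccc(F)cc34)n2)c(OC)cc1N(C)CCN(C)C`: 9700 nM
- compound 3 `CC/C=C\C(=O)Nc1cc(Nc2ncc(C#N)c(-c3cn(C)c4ccc(F)cc34)n2)c(OC)cc1N(C)CCN(C)C`: 4730 nM

In a functional assay on A549 cells (Homo sapiens) for antiproliferative activity, read by MTT assay, with a stated time of 72 h (a higher number here means a weaker inhibitor, a lower number a stronger inhibitor), compound 3 gives 4730 nM, the second highest of the three numbers; compound 2 gives 9700 nM and compound 1 gives 1100 nM. Among the compounds with values here, the one step that bears on the chain is a 2.1-fold lower number from compound 2 to compound 3 (0.31 log units; beyond the scatter), a modest move toward a lower number on extending the chain on the carbonyl carbon. Compound 4 `COc1cc(N(C)CCN(C)C)c(NC(=O)/C=C\C(C)C)cc1Nc1ncc(C#N)c(-c2cn(C)c3ccc(F)cc23)n1` differs from compound 3 by methyl in place of hydrogen on a saturated chain carbon bound to a double-bonded chain carbon and a saturated chain carbon. Within the data shown here, compound 1 carries the same 3-methylbut-1-en-1-yl chain as compound 4 but lacks the fluorine on the indole, and no step isolating that fluorine has been measured, so it gives only a loose anchor. Since the earlier extension of the chain in this assay gave a modest gain, a further small gain or no change beyond the scatter is expected, and the step is estimated as a 1.6-fold lower number from compound 3 to compound 4 (0.20 log units; within the scatter). Compound 4 is therefore expected to give about 3000 nM, within a range from 1200 nM to 8000 nM.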

Compound 4, half-maximal inhibitory concentration: 185 nM
The estimate for compound 4 lay 16-fold (1.21 log units) above the measured number; the whole stated range lies above it.
By their numbers in this assay, from the lowest: compound 4; then compound 1; then compound 3; then compound 2.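

In this assay the step of a 26-fold lower number from compound 3 to compound 4 (1.41 log units; beyond the scatter) shows that one methyl on a saturated chain carbon bound to a double-bonded chain carbon and a saturated chain carbon can outweigh by far the earlier step of a 2.1-fold lower number from compound 2 to compound 3 (0.31 log units; beyond the scatter) on this chain, and the whole change from vinyl gives a 52-fold lower number from compound 2 to compound 4 (1.72 log units; beyond the scatter) in the same assay. The fluorine can now be read too, with fluoro in place of hydrogen on an aromatic carbon giving a 5.9-fold lower number from compound 1 to compound 4 (0.77 log units; beyond the scatter) when the 3-methylbut-1-en-1-yl chain is present. Nothing measured here accounts for these steps.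

As far as these compounds go, whether the fluorine has a similar effect with the vinyl or but-1-en-1-yl chain stays open. So does whether a tert-butyl group, a cyclopropyl group or an amine on the chain would extend this trend or reverse it.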